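Triflyl sulfonamide replacing trifluoromethyl in a thiourea antagonist

A few compounds are considered here, and "the series" means these few. Any claim that something is new, unique, unknown or untested is made for them only; others in the source may bear on it.

Compound 1 `CC(C)(C)c1ccc(C/N=C(\S)NCc2ccc(C(F)(F)F)cc2)cc1` gives 12400 nM in a functional assay for antagonist activity at Vanilloid receptor (Rattus norvegicus) (on this read-out higher numbers stand for weaker inhibition and lower numbers for stronger inhibition), the higher of the two numbers recorded. Compound 2 `CCCS(=O)(=O)Nc1ccc(C/N=C(\S)NCc2ccc(C(C)(C)C)cc2)cc1` gives 4500 nM in this assay, a gap from compound 1 that lies beyond the scatter. Compound 3 `CC(C)(C)c1ccc(C/N=C(\S)NCc2ccc(NS(=O)(=O)C(F)(F)F)cc2)cc1` is derived from compound 1 by a single change, (((trifluoromethyl)sulfonyl)amino in place of trifluoromethyl on an aromatic carbon). Among the compounds with values here, no measured pair shows this exact exchange, so the expected step from compound 1 to compound 3 is estimated as an 8.3-fold lower number from compound 1 to compound 3 (0.92 log units; beyond the scatter), toward stronger inhibition, but with wide uncertainty. Compound 3 is therefore expected to give about 1500 nM in this assay, within a range from 300 nM to 8000 nM.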

Compound 3, half-maximal inhibitory concentration: 12400 nM
For compound 3 the middle estimate is 8.3-fold (0.92 log units) below the measured one, and the stated range ends below it.
By their numbers in this assay, from the lowest: compound 2; then compounds 1 and 3 (each within the scatter of the next).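

At this position, on an aromatic carbon para to a large group, placing ((trifluoromethyl)sulfonyl)amino in place of trifluoromethyl gives no change at the digits printed from compound 1 to compound 3 (within the scatter) in this assay. The read-out therefore does not separate these two groups here, even though the entering group is larger and carries a hydrogen-bond donor and acceptors that trifluoromethyl lacks. Nothing available explains this outcome.

As far as these compounds go, it remains open whether an amine or a carboxylic acid at this place would shift the number. From the compounds shown here alone, it is also open whether the same exchange would leave the number unchanged on another core.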